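A few compounds are considered here, and "the series" means these few. Any claim that something is new, unique, unknown or untested is made for them only; others in the source may bear on it.

Measured compounds:
compound 1 `O=C(NCCCCc1ccccc1)n1c(=O)oc2cc(-c3ccc(F)cc3)ccc21`: 79 nM
compound 2 `O=C(NCCOCc1ccccc1)n1c(=O)oc2ccccc21`: 649 nM

Compound 1 stands lowest of the two numbers; compound 2 lies beyond the scatter from it. Compound 3 `O=C(NCCCCc1ccccc1)n1c(=O)oc2cc(-c3ccccc3)ccc21` differs from compound 1 by one change: hydrogen in place of fluoro on an aromatic carbon. Among the compounds with values here, no measured pair shows this change, so its size is not known from the data. In an assay on HEK293 cells for inhibition of acid ceramidase (Homo sapiens), with a stated time of 10 min (on this read-out lower numbers stand for stronger inhibition and higher numbers for weaker inhibition), the expected step is small, toward a somewhat higher number, possibly not beyond the scatter. The estimate for compound 3 is 110 nM, with a range from 50 nM to 250 nM. This amounts to an expected 1.4-fold higher number from compound 1 to compound 3 (0.14 log units; within the scatter).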

Compound 3, half-maximal inhibitory concentration in the acid ceramidase assay: 84 nM
Beside the measured number, compound 3's estimate is 1.3-fold (0.12 log units) above it, and the stated range covers the measured number.
By their numbers in the acid ceramidase assay, from the lowest: compounds 1 and 3 (each within the scatter of the next); then compound 2.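

Within the data shown here, in the acid ceramidase assay, this is the first direct reading of a change on the aromatic carbon para to a large group: going from 4-fluorophenyl to phenyl gives a 1.1-fold higher number from compound 1 to compound 3 (0.03 log units; within the scatter), so the fluoro can give way to hydrogen here with no step beyond the scatter. In a physicochemical assay for metabolic stability, read by HPLC, in phosphate buffer, at pH 7.4, tested at 10 uM (on this read-out higher numbers stand for a longer-lived compound and lower numbers for a shorter-lived compound), compound 1 gives > 5 h, which is a limit of the assay and not a number. In the physicochemical assay, compound 3 gives > 5 h, which is likewise a limit of the assay and not a number. In the physicochemical assay, the step for the same change cannot be read, since both compounds sit at a limit of the assay: the limit of > 5 h in the physicochemical assay, at which 2 of the 2 values shown sit.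

Going by these compounds, whether an amine or a carboxylic acid at this place would shift the number in the acid ceramidase assay stays open. Also open, on these data alone, is how far the half-life of either compound extends past that limit in the physicochemical assay.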